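The source may report more compounds than this note shows. Statements on the series, on what has been measured and on what is new or still open speak of the compounds shown alone.

Measured in a functional assay on RKO cells (Homo sapiens) for cytotoxicity, read by resazurin assay, with a stated time of 72 h; a higher number here means a weaker inhibitor, a lower number a stronger inhibitor:
- Compound 1 `Cc1nccn1-c1csc(Nc2cccc(Br)c2)n1`: > 100000 nM (a limit)
- Compound 2 `COc1ccc(Nc2nc(-n3ccnc3C)cs2)cc1`: > 100000 nM (a limit)
- Compound 3 `c1ccc(Nc2nc(-n3ccnc3)cs2)cc1`: > 100000 nM (a limit)

Compound 3 gives only a limit, > 100000 nM, and not a number. The other two compounds give no number either: the limit of > 100000 nM in this assay, at which 3 of the 3 values shown sit.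

Compound 4 `Cc1nccn1-c1csc(Nc2ccccc2)n1` has methyl in place of hydrogen on an aromatic carbon, between two ring nitrogen atoms, turning 1H-imidazol-1-yl into 2-methyl-1H-imidazol-1-yl: methyl in place of hydrogen on an aromatic carbon.

Compound 1 already carries this group and gives the limit > 100000 nM. Compound 2 carries it too and gives the limit > 100000 nM. No step beyond the usual scatter is therefore expected in this assay, and another limit is the likeliest result. The expected change is a number no higher from compound 3 to compound 4 (the limit leaves the size open). For compound 4 the estimate is 100000 nM, with an expected range of 40000 nM to 200000 nM.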

Compound 4, half-maximal inhibitory concentration: > 100000 nM
Compound 4 ended at the assay's limit; the forecaster's own chance of this, stated with the estimate: 85%; the middle value lies on the limit itself.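

Compound 4 also gives only a limit, so no step can be read among compound 1, compound 2, compound 3 and compound 4 in this assay: the limit of > 100000 nM in this assay, at which 4 of the 4 values shown sit. The true strength of these compounds, and whether methyl, methoxy or bromo alters it, stays open.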